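A few compounds are considered here, and "the series" means these few. Any claim that something is new, unique, unknown or untested is made for them only; others in the source may bear on it.

Compound 1 `C=C(C)[C@@H]1CC=C(C)/C(=N/NC(=O)Nc2nnc(-c3ccc(Cl)cc3)o2)C1`: 300 mg/kg
Compound 2 `C=C(C)[C@@H]1CC=C(C)/C(=N/NC(=O)Nc2nnc(-c3ccc(OC)cc3)o2)C1`: 300 mg/kg
Compound 3 `C=C(C)[C@@H]1CC=C(C)/C(=N/NC(=O)Nc2nnc(-c3ccc([N+](=O)[O-])cc3)o2)C1`: not yet measured

The two measured compounds share one core and differ only in the group carried on the six-membered aromatic ring. In a functional assay on the whole organism (strain Swiss albino) with Mus musculus as the target, with a stated time of 4 h (on this read-out higher numbers stand for an effect only at larger amounts of compound and lower numbers for an effect already at smaller amounts), compound 1 gives 300 mg/kg. In this assay compound 2 gives 300 mg/kg, so compound 2 stands level with compound 1 at the digits shown, and the step of no change at the digits printed from compound 1 to compound 2 (within the scatter) lies within the usual scatter of such measurements.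

Compound 3 differs from compound 2 by nitro in place of methoxy on an aromatic carbon. Within the data shown here, only one measured step bears on this change: the exchange of the group at the same place, from compound 1 to compound 2, which left the read-out unchanged. Among the measured compounds shown here, no nitro-bearing compound has been measured, so that step is the sole guide, and a loose one.

On this basis a step of no change at the digits printed from compound 2 to compound 3 (within the scatter) is expected, that is, none beyond the scatter. Compound 3 is therefore estimated at 300 mg/kg, with a range from 150 mg/kg to 600 mg/kg.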

Compound 3, minimum effective dose: 300 mg/kg
Compound 3: the middle estimate sits on the measured number at the digits printed; measured number inside the range.
By their numbers in this assay, from the lowest: compounds 1, 2 and 3 (each within the scatter of the next).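

In this assay, nitro in place of methoxy gives no change at the digits printed from compound 2 to compound 3 (within the scatter), and nitro in place of chloro on the same aromatic carbon gives no change at the digits printed from compound 1 to compound 3 (within the scatter). The earlier pair showed only that chloro and methoxy read alike, whereas three different groups at this one place, on the six-membered aromatic ring and para to a large group, now share a single read-out, so none of the exchanges among these three compounds moves the minimum effective dose beyond the scatter. Nothing on hand explains why the read-out stays level across these groups.

The compounds shown leave open whether an amine, a carboxylic acid or a longer chain such as butoxy at this same place would move the read-out away from the level shared by compounds 1, 2 and 3, or whether an unsubstituted phenyl ring would read the same. They also leave open what a change anywhere in the shared core would do, as all three compounds differ only in this one group.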